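The source may report more compounds than this note shows. Statements on the series, on what has been measured and on what is new or still open speak of the compounds shown alone.

Compound 1, with the structure `O=C1C=C(Nc2cccc(F)c2)C(=O)c2c1nc1n2[C@H]2OC[C@@H](O)[C@H]2OC1`, was tested in a functional assay on MGC-803 cells (Homo sapiens) for inhibition, read by sulforhodamine B assay (on this read-out higher numbers stand for weaker inhibition and lower numbers for stronger inhibition), where compound 1 gives 2180 nM. Its companion, compound 2, with the structure `O=C1C(Nc2ccc(C(F)(F)F)cc2)=CC(=O)c2c1nc1n2[C@H]2OC[C@@H](O)[C@H]2OC1`, gives 1860 nM in this assay. Compound 1 carries the higher of the two numbers, but the two values sit so close that they fall within the usual scatter of repeated measurements, so nothing can be said about one being stronger than the other.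

The next compound, compound 3, with the structure `O=C1C=C(Nc2cccc(Cl)c2)C(=O)c2c1nc1n2[C@H]2OC[C@@H](O)[C@H]2OC1`, is built on the same shared core and differs from compound 1 in a single place: chloro in place of fluoro on an aromatic carbon. Among the measured compounds shown here, no measured pair in this set shows what such an exchange does here, so the expectation rests on its small size alone. Compound 3 is expected to stay within the scatter of compound 1, the step from compound 1 to compound 3 being estimated as a 1.2-fold lower number from compound 1 to compound 3 (0.08 log units; within the scatter), and compound 3 is estimated at 1800 nM, with a range from 800 nM to 4000 nM.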

Compound 3, half-maximal inhibitory concentration: 1770 nM
Estimate against measurement, compound 3: 1.0-fold (0.01 log units) above; the measured number falls inside the stated range.
By their numbers in this assay, from the lowest: compounds 3, 2 and 1 (each within the scatter of the next).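

In this assay, among the compounds shown here, putting chloro in place of fluoro on the aromatic carbon gives a 1.2-fold lower number from compound 1 to compound 3 (0.09 log units; within the scatter) and provides the first single-place comparison in this set. At this place on the 3-fluorophenyl group, the two halogens therefore cannot be told apart on this read-out, since the change between them does not exceed the ordinary variation between repeated measurements. Nothing measured here gives a reason for this result.

From the compounds shown here alone, it remains open whether the same place would respond so little to a group of another kind, such as a methoxy group, an amine or a carboxylic acid. Going by these compounds, the effect of removing the halogen altogether, leaving a plain phenyl group, also remains unknown, as does the effect of a heavier halogen such as bromo.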